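A few compounds are considered here, and "the series" means these few. Any claim that something is new, unique, unknown or untested is made for them only; others in the source may bear on it.

Measured in a functional assay on the whole organism (Tail, strain ICR) with Mus musculus as the target, in the tail flick test, with a stated time of 120 min, at a dose of 25 umol/kg by the oral route; a lower number here means a weaker effect, a higher number a stronger effect of the compound at the dose given:
Compound 1, `O=C(CN(c1nc(Cl)nc2[nH]cnc12)C1CC1)N[C@@H](CC(=O)OCc1ccccc1)C(=O)OCc1ccccc1`, gives 12.1%.
Compound 2, `NC(=O)CC[C@H](NC(=O)CN(c1ncnc2c1ncn2C1CCCCO1)C1CC1)C(=O)OCc1ccccc1`, gives 22.3%.
Compound 3, `C[C@H](NC(=O)CN(c1nc(Cl)nc2[nH]cnc12)C1CC1)C(=O)OCc1ccccc1`, gives 36.1%.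

Compound 2 stands second highest of the three numbers, above compound 1 and below compound 3, both gaps beyond the scatter. Compound 4, `NC(=O)C[C@H](NC(=O)CN(c1ncnc2c1ncn2C1CCCCO1)C1CC1)C(=O)OCc1ccccc1`, differs from compound 2 in one place: carbamoyl in place of carbamoylmethyl on a saturated chain carbon, two bonds along the chain from an amide-type nitrogen and a carbonyl carbon. For the measured compounds named here, the only measured step at that place is a number 24 percentage points higher from compound 1 to compound 3 (beyond the scatter), in which a benzyloxycarbonyl gave way to hydrogen; that is a different and larger cut than trimming carbamoylmethyl to carbamoyl, so it bears only loosely here. A small rise is plausible, but the step is expected to stay within the scatter. Compound 4 is therefore estimated at 26%, with a range from 13% to 40%, an expected step of a number 3.7 percentage points higher from compound 2 to compound 4 (within the scatter).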

Compound 4, a percentage reported as activity, at one dose (the size of the read-out at that dose, not a potency): 29.2%
Estimate against measurement, compound 4: 3.2 percentage points below; the measured number falls inside the stated range.
By their numbers in this assay, from the lowest: compound 1; then compounds 2, 4 and 3 (each within the scatter of the next, the first and the last beyond it).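

Replacing carbamoylmethyl with carbamoyl on this saturated chain carbon gives a number 6.9 percentage points higher from compound 2 to compound 4 (within the scatter) in this assay. The same difference, cut one bond further out, reads 2-carbamoylethyl to carbamoylmethyl, so this pair shows that these two chain lengths are not separated by this read-out at this dose. No measurement here offers an explanation for this result. Still open, on these data alone, is how a carboxylic acid, an amine or a longer chain ending in carbamoyl would read at this place.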